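Dimethylamino to morpholin-4-yl, starting from a limit

The source may report more compounds than this note shows. Statements on the series, on what has been measured and on what is new or still open speak of the compounds shown alone.

Measured in an ADME assay on HeLa cells (Homo sapiens) for inhibition, read by MTT assay, with a stated time of 48 h; a higher number here means a weaker inhibitor, a lower number a stronger inhibitor:
Compound 1 `C=C(C)Cn1cc(/C=C/C(=O)CC(=O)C(=O)O)c2ccccc21`: 40000 nM
Compound 2 `CN(C)C(=O)Cn1cc(/C=C/C(=O)CC(=O)C(=O)O)c2ccccc21`: > 40000 nM

Compound 2 has no exact number on this scale: its > 40000 nM is a limit of the assay. That places it at the limit of > 40000 nM in this assay, at which 1 of the 2 values shown sits.

Compound 3 `O=C(/C=C/c1cn(CC(=O)N2CCOCC2)c2ccccc12)CC(=O)C(=O)O` keeps the shared core and differs from compound 2 in one group: morpholin-4-yl in place of dimethylamino on a carbonyl carbon. In words, morpholin-4-yl takes the place of dimethylamino on a carbonyl carbon.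

Going by the values given here, only one measured step bears on this change, a number no lower from compound 1 to compound 2 (the limit leaves the size open). It swaps a different group, and its size cannot be read, so it offers no size to carry over. No step beyond the scatter is therefore expected in this assay, and no direction is favoured. The estimated step is a number no higher from compound 2 to compound 3 (the limit leaves the size open).

The expected value for compound 3 is 40000 nM, with an expected range from 20000 nM to 80000 nM.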

Compound 3, half-maximal inhibitory concentration: > 40000 nM
Compound 3: no number, only a limit; the forecaster's own chance of this, stated with the estimate: 70%; the middle value lies on the limit itself.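

In this assay compound 3 also has only a limit and not a number, so it sits with compound 2 at the end of the scale: the limit of > 40000 nM in this assay, at which 2 of the 3 values shown sit. With (morpholin-4-yl)carbonyl in place of 1-methylethenyl on a saturated chain carbon bound to an aromatic nitrogen, the data give a number no lower from compound 1 to compound 3 (the limit leaves the size open). What is new is that a ring-bearing group, morpholin-4-yl, on the same carbonyl carbon also gives a limit, just as dimethylamino does. The step between these two limits cannot be read, so neither a size nor a direction can be given for this change.

The compounds shown leave open whether an amine or a carboxylic acid on the saturated chain carbon bound to the aromatic nitrogen would give a true number on this scale. They also leave open how far compound 2 and compound 3 lie beyond their shared limit.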